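The compounds below may be only part of what the source reports. "The series", "measured", "known", "first", "only" and "open" are said of these compounds alone.

Compound 1 `Cc1nnc(SCC(=O)N/N=c2/scc(-c3ccccc3)n2-c2ccccc2)s1` gives > 200 ug/mL in a functional assay on C6 cells (Rattus norvegicus) for cytotoxicity, read by MTT assay, with a stated time of 24 h; a lower number here means a stronger inhibitor, a higher number a weaker inhibitor; this is a limit of the assay, not a number. Compound 2 `Cc1nnc(SCC(=O)N/N=c2/scc(-c3ccc(F)cc3)n2-c2ccccc2)s1` in this assay gives 27.3 ug/mL. Compound 3 `Cn1cnnc1SCC(=O)N/N=c1/scc(-c2ccc(F)cc2)n1-c1ccccc1` in this assay has "not determined" (no result reported), so no result is reported for it.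

Compounds 2 and 1 share a core and differ by hydrogen in place of fluoro on an aromatic carbon; this change gave an at least 7.3-fold higher number from compound 2 to compound 1 (0.86 log units; beyond the scatter). Compound 3 differs from compound 2 in the core by 4-methyl-4H-1,2,4-triazol-3-yl in place of 5-methyl-1,3,4-thiadiazol-2-yl on a sulfur. Compound 4 `Cn1cnnc1SCC(=O)N/N=c1/scc(-c2ccccc2)n1-c1ccccc1` differs from compound 3 by hydrogen in place of fluoro on an aromatic carbon, the same change, at the same place, as from compound 2 to compound 1.

With no number for compound 3, the expectation for compound 4 can rest only on compound 1, which sits at the limit of > 200 ug/mL in this assay, at which 1 of the 3 values shown sits, and on the step from compound 2 to compound 1. Compound 4 is expected to be a weak inhibitor, near 200 ug/mL, with an estimated range from 80 ug/mL to 400 ug/mL, and a limit rather than a number is quite likely.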

Compound 4, half-maximal inhibitory concentration: 68.3 ug/mL
For compound 4 the middle estimate is 2.9-fold (0.47 log units) above the measured one; measured number below the stated range.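

In this assay, with phenyl in both compounds, putting 4-methyl-4H-1,2,4-triazol-3-yl in place of 5-methyl-1,3,4-thiadiazol-2-yl on the sulfur gave an at least 2.9-fold lower number from compound 1 to compound 4 (0.46 log units; beyond the scatter). From the compounds shown here alone, compound 1 stands at a limit of the assay, not a number, so the full size of this step stays unknown: the limit of > 200 ug/mL in this assay, at which 1 of the 4 values shown sits. Compound 3 has no result, and the steps that involve it cannot be read; whether this swap, or the change from 4-fluorophenyl to phenyl, carries over from one core to the other therefore remains unshown.

The compounds shown leave open what a chloro or methoxy group would do in place of the fluoro. They also leave open what an ethyl group would do in place of the methyl on either sulfur-bound group.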